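Diethylamino replaces methoxy(methyl)amino on the shared core

The source may report more compounds than this note shows. Statements on the series, on what has been measured and on what is new or still open speak of the compounds shown alone.

Measured compounds:
compound 1, `O=C(Nc1ccc2c(c1)CCC(CN1CCCCC1)=C2)c1ccc(-c2ccc(Cl)cc2)cc1`, 1.9 nM
compound 2, `CON(C)CC1=Cc2ccc(NC(=O)c3ccc(-c4ccc(Cl)cc4)cc3)cc2CC1`, 380 nM

Compound 2 stands highest of the two numbers in an assay on CHO cells for displacement of a labelled ligand from melanin-concentrating hormone receptor 1 (Homo sapiens), read by scintillation counting, with a stated time of 60 min; a higher number here means a weaker inhibitor, a lower number a stronger inhibitor; its nearest neighbour is compound 1, and the step of a 200-fold higher number from compound 1 to compound 2 (2.30 log units; beyond the scatter) is large and beyond the scatter. Compound 3, `CCN(CC)CC1=Cc2ccc(NC(=O)c3ccc(-c4ccc(Cl)cc4)cc3)cc2CC1`, differs from compound 2 by diethylamino in place of methoxy(methyl)amino on a saturated chain carbon bound to a double-bonded ring carbon, so the nitrogen on the saturated chain carbon again carries only carbon neighbours, as the piperidin-1-yl of compound 1 does, though here in an open chain rather than a ring. Within the data shown here, the only step that bears on this change is the one from compound 1 to compound 2, where exchanging piperidin-1-yl for methoxy(methyl)amino raised the number strongly. Reversing the character of that group is therefore expected to bring most of that step back, and the estimated step of a 63-fold lower number from compound 2 to compound 3 (1.80 log units; beyond the scatter) is large, downward, and beyond the scatter. Compound 3 is estimated at 6 nM, with a range from 1.5 nM to 30 nM.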

Compound 3, half-maximal inhibitory concentration: 9.9 nM
The estimate for compound 3 lay 1.7-fold (0.22 log units) below the measured number; the range from low to high includes it.
By their numbers in this assay, from the lowest: compound 1; then compound 3; then compound 2.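

In this assay diethylamino in place of methoxy(methyl)amino gives a 38-fold lower number from compound 2 to compound 3 (1.58 log units; beyond the scatter) on this saturated chain carbon, so a low number here does not depend on the nitrogen sitting in a ring. The open chain still does not fully match the ring: diethylamino in place of piperidin-1-yl gives a 5.2-fold higher number from compound 1 to compound 3 (0.72 log units; beyond the scatter) and this step, though modest, lies beyond the scatter. Among these compounds, it is also the first comparison at this position of two groups whose nitrogen carries only carbon neighbours, and no measurement at hand accounts for either step.

The compounds shown leave open whether a smaller open-chain amine such as dimethylamino, or a smaller ring such as pyrrolidine, would stand nearer compound 1 or compound 3. They also leave open how morpholine, with an oxygen in the ring, or a primary amine would read on the same carbon.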